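The compounds below may be only part of what the source reports. "The series", "measured", "known", "first", "only" and "open" are said of these compounds alone.

Measured so far in a functional assay on HEK293 cells for antagonist activity at thromboxane A2 receptor (Homo sapiens), read by fluorescence and calcium flux; on this read-out higher numbers stand for weaker inhibition and lower numbers for stronger inhibition:

compound 1 `CC(C)(C)NC(=O)NS(=O)(=O)c1cc(C#N)ccc1Oc1ccc(Cl)cc1` gives 5270 nM
compound 2 `CC(C)(C)NC(=O)NS(=O)(=O)c1cc(C#N)ccc1Oc1ccc(Br)cc1` gives 5310 nM

Compound 2 holds the highest of the two numbers in this assay, but its nearest neighbour, compound 1, sits so close that the step of a 1.0-fold higher number from compound 1 to compound 2 (0.00 log units; within the scatter) lies within the scatter; the two compounds cannot be told apart on this read-out. Among the measured compounds shown here, that step, bromo in place of chloro on the outer ring, is the only measured comparison available.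

Compound 3 `Cc1ccc(Nc2ccc(C#N)cc2S(=O)(=O)NC(=O)NC(C)(C)C)cc1` differs from compound 2 in one place: (4-methylphenyl)amino in place of 4-bromophenoxy on an aromatic carbon. For the measured compounds named here, no measured pair shows a replacement of this kind, so the one step that exists, a 1.0-fold higher number from compound 1 to compound 2 (0.00 log units; within the scatter), bears on it only loosely: it shows that changing the halogen on the outer ring left the number where it was, and says nothing about swapping the ether linkage for an amine and the halogen for a methyl group at once.

Going by the values given here, with no bearing step, compound 3 is expected to land near compound 2, and the expected step of a 1.2-fold lower number from compound 2 to compound 3 (0.07 log units; within the scatter) is given a wide range. Compound 3 is estimated at 4500 nM, between 1200 nM and 17000 nM.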

Compound 3, half-maximal inhibitory concentration: 1040 nM
Beside the measured number, compound 3's estimate is 4.3-fold (0.64 log units) above it; the measured number lies below the stated range.
By their numbers in this assay, from the lowest: compound 3; then compounds 1 and 2 (each within the scatter of the next).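

In this assay, the group on the aromatic carbon para to a cyano group proves able to move the number, as the halogen exchange on the outer ring did not: (4-methylphenyl)amino in place of 4-bromophenoxy gives a 5.1-fold lower number from compound 2 to compound 3 (0.71 log units; beyond the scatter) and in place of 4-chlorophenoxy gives a 5.1-fold lower number from compound 1 to compound 3 (0.70 log units; beyond the scatter) with the same result. Both steps lie beyond the scatter, which makes compound 3 the strongest inhibitor of the three shown, though the change is modest in size. The entering group has the same heavy-atom count as the group it replaces and adds a hydrogen-bond donor, but the compounds shown offer no measurement that explains the shift.

The linking atom and the substituent on the outer ring change together here, so the compounds shown leave open which of the two carries the shift. From the compounds shown here alone, a 4-methylphenoxy group or a (4-bromophenyl)amino group at this position would separate them, and how an ethyl group or a methoxy group in place of the methyl would read on this assay also remains open.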